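The source may hold more compounds than are shown below. What is called first, only, known or untested is meant among the compounds shown, and "the series" means these compounds.

The measured compounds and their numbers in an in vitro ADME assay on microsomes from liver (Homo sapiens) for metabolic stability; on this read-out higher numbers stand for fast clearance and lower numbers for slow clearance:
compound 1 `CC(C)Nc1nccc(-c2c[nH]nc2C2CCOCC2)n1` gives 0.018 mL/min/kg
compound 2 `Clc1ccc(-c2n[nH]cc2-c2ccnc(NC3CCCCC3)n2)cc1` gives 0.156 mL/min/kg
compound 3 `Clc1ccc(-c2n[nH]cc2-c2ccnc(NC3CC3)n2)cc1` gives 0.096 mL/min/kg

Compound 1 stands lowest of the three in this assay; compound 3 is nearest to it, at a gap beyond the scatter, and compound 2 is furthest, also beyond the scatter. Within the data shown here, the single step between measured pairs, a 1.6-fold lower number from compound 2 to compound 3 (0.21 log units; within the scatter), concerns a cyclopropyl in place of a cyclohexyl on a nitrogen on an aromatic ring and stays within the scatter.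

Compound 4 `CC(C)Nc1nccc(-c2c[nH]nc2C2CCCOC2)n1` differs from compound 1 in one place: oxan-3-yl in place of oxan-4-yl on an aromatic carbon. The two have the same atoms, joined differently, with oxan-3-yl taking the place of oxan-4-yl on an aromatic carbon of the five-membered aromatic ring with 2 nitrogen. Among the measured compounds shown here, no measured step moves this group; the only step that exists touches a different part of the shared core and remained within the scatter. There is thus nothing in the numbers to ground a shift in either direction, and the step expected from compound 1 to compound 4 is no change at the digits printed from compound 1 to compound 4 (within the scatter), none beyond the scatter. Compound 4 is therefore estimated at 0.018 mL/min/kg, with a range from 0.009 mL/min/kg to 0.036 mL/min/kg.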

Compound 4, clearance: 0.034 mL/min/kg
For compound 4 the middle estimate is 1.9-fold (0.28 log units) below the measured one, within the range that was stated.
By their numbers in this assay, from the lowest: compounds 1 and 4 (each within the scatter of the next); then compounds 3 and 2 (each within the scatter of the next).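

In this assay, the exchange of oxan-4-yl for oxan-3-yl on an aromatic carbon of the five-membered aromatic ring with 2 nitrogen gives a 1.9-fold higher number from compound 1 to compound 4 (0.28 log units; within the scatter), so this change of attachment, with the same atoms joined differently, does not separate the two compounds on this read-out. This is the first step shown at this position, as the only earlier step concerned the group on the nitrogen, and it indicates that, for this pair at least, the point at which the oxane ring is joined to the shared core can differ without a shift beyond the scatter. No evidence is available that bears on this result.

Among these compounds, the pair shows only two closely matched groups at this position, so it remains open whether a piperidine, a morpholine or a simple methyl group there would keep the number in the same region. Going by these compounds, it also remains open whether the same exchange of oxan-4-yl for oxan-3-yl would read alike with a cyclopropyl or a cyclohexyl on the nitrogen of the shared core.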